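Working notes on aryl swaps, compound 3 to compound 4

A few compounds are considered here, and "the series" means these few. Any claim that something is new, unique, unknown or untested is made for them only; others in the source may bear on it.

- compound 1 `CNC(=O)c1cc(Oc2ccc(C(=O)/C=C/c3cccc(Br)c3)cc2)ccn1`: 9940 nM
- compound 2 `CNC(=O)c1cc(Oc2ccc(C(=O)/C=C/c3ccc(Cl)c(Cl)c3)cc2)ccn1`: 33700 nM
- compound 3 `CNC(=O)c1cc(Oc2ccc(C(=O)/C=C/c3ccc(OC)cc3)cc2)ccn1`: > 50000 nM (a limit)
- compound 4 `CNC(=O)c1cc(Oc2ccc(C(=O)/C=C/c3cccc(Cl)c3Cl)cc2)ccn1`: not yet measured

All values come from a functional assay on A549 cells (Homo sapiens) for cytotoxicity, read by MTT assay, with a stated time of 72 h; on this read-out lower numbers stand for stronger inhibition and higher numbers for weaker inhibition. Compound 3 has only a limit, > 50000 nM, and no number.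

The change is 2,3-dichlorophenyl in place of 4-methoxyphenyl on a double-bonded chain carbon bound to a double-bonded chain carbon.

Among the compounds with values here, two measured steps bear on it: an at least 5.0-fold higher number from compound 1 to compound 3 (0.70 log units; beyond the scatter), and an at least 1.4-fold higher number from compound 2 to compound 3 (0.17 log units; that floor lies within the scatter), whose floor lies within the scatter. The spread among the halogen-bearing compounds, a 3.4-fold higher number from compound 1 to compound 2 (0.53 log units; beyond the scatter), sets the width of the expectation. Compound 4 carries a dichlorophenyl group, as does compound 2 at 33700 nM, so a modest step to a lower number is expected. The estimated step is an at least 2.7-fold lower number from compound 3 to compound 4 (0.44 log units; beyond the scatter). The estimate for compound 4 is 18000 nM, with an expected range of 6000 nM to 50000 nM.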

Compound 4, half-maximal inhibitory concentration: > 50000 nM
Compound 4: only a limit was reported (the forecaster's own chance of this, stated with the estimate: 15%); at least 2.7-fold (0.44 log units) between middle value and limit.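

In this assay compound 4 gives only a limit, and with compound 3 also at a limit, the step between them cannot be read: the limit of > 50000 nM in this assay, at which 2 of the 4 values shown sit.

The 2,3-dichlorophenyl group, set against 3-bromophenyl, gives an at least 5.0-fold higher number from compound 1 to compound 4 (0.70 log units; beyond the scatter), so reaching the limit at this place is not confined to 4-methoxyphenyl. Set against 3,4-dichlorophenyl, it gives an at least 1.4-fold higher number from compound 2 to compound 4 (0.17 log units; that floor lies within the scatter), a floor that does not separate the two dichlorophenyl compounds.

On these data alone, whether compound 3 and compound 4 differ at all remains open. Also open, as far as these compounds go, is how a phenyl ring bearing an amine or a carboxylic acid would read at this place.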